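This account rests on a few compounds, and the source may have more. Where it says the series, first, only, none or still open, it means among the compounds named here.

Measured so far, in a functional assay on the whole organism (strain Wistar) with Rattus norvegicus as the target, with a stated time of 5 min; a higher number here means that more compound is needed for the effect, a lower number that less compound is needed:

compound 1, `CCC1(CCCCN2CCN(c3ccc(F)cc3)CC2)C(=O)Nc2ccccc21`: 10 mg/kg
compound 2, `CCC1(CCCCN2CCN(c3ccc(F)c(Cl)c3)CC2)C(=O)Nc2ccccc21`: a limit, > 20 mg/kg
compound 3, `CCC1(CCCCN2CCN(c3ccc(Cl)cc3)CC2)C(=O)Nc2ccccc21`: 10 mg/kg

Compound 3 stands level with compound 1, since no change at the digits printed from compound 1 to compound 3 (within the scatter). The value of compound 2 is a limit of this assay and not a number (the limit of > 20 mg/kg in this assay, at which 1 of the 3 values shown sits). Compound 4, `CCC1(CCCCN2CCN(c3ccccc3Cl)CC2)C(=O)Nc2ccccc21`, has not been measured. It differs from compound 3 in one place: 2-chlorophenyl in place of 4-chlorophenyl on an amine nitrogen in a ring. Within the data shown here, no measured step moves a chlorine from one position on the phenyl ring to another, so the closest guidance is indirect. Exchanging one halogen for another gave no change at the digits printed from compound 1 to compound 3 (within the scatter), while adding a second halogen gave an at least 2.0-fold higher number from compound 1 to compound 2 (0.30 log units; that floor lies within the scatter), and its removal gave an at least 2.0-fold lower number from compound 2 to compound 3 (0.30 log units; that floor lies within the scatter). The change to compound 4 keeps one chlorine, so no step beyond the scatter is expected in this assay, with a slight lean toward a higher number. Compound 4 is expected to give 15 mg/kg, between 5 mg/kg and 30 mg/kg. This estimate means a step of a 1.5-fold higher number from compound 3 to compound 4 (0.18 log units; within the scatter), which is expected to stay within the scatter.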

Compound 4, minimum effective dose: > 20 mg/kg
Compound 4 was reported as a limit; the forecaster's own chance of this, stated with the estimate: 25%; middle value at least 1.3-fold (0.12 log units) away from the limit.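

Among these compounds, the earlier compounds only changed which halogens the phenyl ring carried, whereas this is the first step that keeps the same atoms and changes only where the chlorine sits on the ring. In this assay, 2-chlorophenyl in place of 4-chlorophenyl gives an at least 2.0-fold higher number from compound 3 to compound 4 (0.30 log units; that floor lies within the scatter), and the comparison with the 4-fluorophenyl compound gives an at least 2.0-fold higher number from compound 1 to compound 4 (0.30 log units; that floor lies within the scatter), so a single chlorine can go with a higher dose requirement depending on its position, though neither floor clears the usual scatter. The value of compound 4 is a limit and not a number: the limit of > 20 mg/kg in this assay, at which 2 of the 4 values shown sit.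

The step between compound 2 and compound 4 cannot be read, since both values are limits. Also open, going by these compounds, is whether a plain phenyl group or a methoxyphenyl group on the same ring nitrogen would stay level with compound 3 or reach that limit.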